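Working notes: from acid compound 2 to cyclohexyl amide

The source may hold more compounds than are shown below. What is called first, only, known or untested is meant among the compounds shown, and "the series" means these compounds.

Measured in a functional assay on HT-29 cells (Homo sapiens) for antiproliferative activity, read by MTT assay, with a stated time of 72 h; on this read-out higher numbers stand for weaker inhibition and lower numbers for stronger inhibition:
- Compound 1 `C=CC(=O)N(CC(=O)OCC)c1nc(-c2ccccc2)cs1`: 19000 nM
- Compound 2 `C=CC(=O)N(CC(=O)O)c1nc(-c2ccccc2)cs1`: > 30000 nM (a limit of the assay)

Compound 2 has no numerical value on this read-out, only (the limit of > 30000 nM in this assay, at which 1 of the 2 values shown sits). Compound 3 `C=CC(=O)N(CC(=O)NC1CCCCC1)c1nc(-c2ccccc2)cs1` has not yet been measured. It differs from compound 2 by cyclohexylamino in place of hydroxy on a carbonyl carbon.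

Within the data shown here, the one measured step that bears on this change is an at least 1.5-fold higher number from compound 1 to compound 2 (0.19 log units; that floor lies within the scatter). Among the measured compounds shown here, that step concerns hydrogen in place of ethyl, and compound 1 is the only compound with a measured number, at 19000 nM. Compound 3 likewise carries something other than hydroxy on that carbonyl carbon, so a modest step towards a lower number, meaning stronger inhibition, is expected in this assay, although a reading at the limit remains possible.

For compound 3 the expected value is 14000 nM, with an estimated range from 4000 nM to 30000 nM.

The estimated step is an at least 2.1-fold lower number from compound 2 to compound 3 (0.33 log units; beyond the scatter).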

Compound 3, half-maximal inhibitory concentration: > 30000 nM
Compound 3: a limit, no number (the forecaster's own chance of this, stated with the estimate: 30%); middle value at least 2.1-fold (0.33 log units) away from the limit.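

In this assay compound 3 gives > 30000 nM, which is a limit of the assay and not a number. Cyclohexylamino in place of hydroxy on this carbonyl carbon therefore yields no readable step, as both ends of that change are limits, and the series now gathers at one reading: the limit of > 30000 nM in this assay, at which 2 of the 3 values shown sit. Cyclohexylamino in place of ethoxy on the same carbonyl carbon gives an at least 1.5-fold higher number from compound 1 to compound 3 (0.19 log units; that floor lies within the scatter), so this pair sets no order between the two groups, but it does show that replacing hydroxy with a larger group, here one carrying a six-membered non-aromatic ring, does not by itself bring a reading inside the range of the assay.

Among these compounds, compound 1 thus remains the only compound with a number, and how far compound 2 and compound 3 lie past the limit cannot be told. On these data alone, whether a smaller amine such as methylamino, or an alkoxy group with a longer chain such as butoxy, on this carbonyl carbon would give a number stays open.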